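A few compounds are considered here, and "the series" means these few. Any claim that something is new, unique, unknown or untested is made for them only; others in the source may bear on it.

Measured compounds:
compound 1 `CN(CC1CCC/C(=C\c2ccccc2)C1=O)c1ccccc1`: 49.7%
compound 2 `Cc1ccc(N(C)CC2CCC/C(=C\c3ccccc3)C2=O)cc1`: 18.3%
compound 3 `Cc1cccc(N(C)CC2CCC/C(=C\c3ccccc3)C2=O)c1`: 44.9%

In a functional assay on the whole organism (Ear, strain Kunming) for inhibition, with Mus musculus as the target, with stated times of 1 h and 30 min, at a dose of 200 mg/kg by the oral route (on this read-out higher numbers stand for more inhibition at the one dose given (going by the name of the read-out) and lower numbers for less inhibition), compound 1 holds the highest of the three numbers; compound 3 sits within the scatter of it, while compound 2 lies well below, beyond the scatter. Compound 4 `Cc1ccc(/C=C2\CCCC(CN(C)c3ccccc3)C2=O)cc1` differs from compound 1 by methyl in place of hydrogen on an aromatic carbon. The two measured steps of the same kind, methyl in place of hydrogen on an aromatic carbon, put the methyl on the ring attached to the amine nitrogen and went apart: a number 31.4 percentage points lower from compound 1 to compound 2 (beyond the scatter), whereas a number 4.8 percentage points lower from compound 1 to compound 3 (within the scatter). Compound 4 carries the methyl on the other ring, so neither step bears on it directly; a small to modest loss is expected, with wide uncertainty. Compound 4 is estimated at 38%, range 15% to 55%, meaning a number 11.7 percentage points lower from compound 1 to compound 4 (beyond the scatter).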

Compound 4, a percentage reported as inhibition, in the whole organism at one dose (the size of the read-out at that dose, not a potency): 39.5%
For compound 4 the middle estimate is 1.5 percentage points below the measured one; low and high end bracket the measured number.
By their numbers in this assay, from the lowest: compound 2; then compounds 4, 3 and 1 (each within the scatter of the next, the first and the last beyond it).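

In this assay, the change from phenyl to 4-methylphenyl on the ring not bound to the amine nitrogen gives a number 10.2 percentage points lower from compound 1 to compound 4 (beyond the scatter). So a methyl on this second ring also lowers the number, a loss the earlier compounds could not show, as their methyls sat only on the ring at the amine nitrogen. No available evidence accounts for this loss. As far as these compounds go, whether a chlorine, a fluorine or a methoxy group at this position would give a similar number stays open. So does the effect of a methyl elsewhere on this ring.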